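The source may hold more compounds than are shown below. What is called first, only, known or untested is meant among the compounds shown, and "the series" means these compounds.

Measured in a functional assay on brain (Rattus norvegicus, strain Wistar) for inhibition; on this read-out higher numbers stand for weaker inhibition and lower numbers for stronger inhibition:
- Compound 1 `CCCCOc1ccc(-c2c(C)[nH]c(=O)n2C)cc1`: 5100 nM
- Compound 2 `CCCCn1c(-c2ccccc2)c(C)[nH]c1=O`: > 100000 nM (a limit of the assay, not a number)
- Compound 3 `Cc1[nH]c(=O)n(C2CCCCC2)c1-c1ccccc1`: 47600 nM

Of the two true numbers, compound 3 holds the higher one, so it inhibits more weakly than compound 1, and the gap lies beyond the scatter. Compound 4 `CCCCOc1ccc(-c2c(C)[nH]c(=O)n2C2CCCCC2)cc1` is compound 3 with one change, butoxy in place of hydrogen on an aromatic carbon.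

Among the measured compounds shown here, no measured step makes this exact change. For the measured compounds named here, the only measured step, an at least 2.1-fold lower number from compound 2 to compound 3 (0.32 log units; beyond the scatter), swaps butyl for cyclohexyl on an aromatic nitrogen and favours cyclohexyl, though it starts from a limit. The closest clue is compound 1 at 5100 nM, which already carries butoxy, with methyl where compound 3 has cyclohexyl. A clear drop in the number is therefore expected, though its size is uncertain, with an expected step of a 16-fold lower number from compound 3 to compound 4 (1.20 log units; beyond the scatter). For compound 4 the estimated value is 3000 nM, with an expected range of 400 nM to 20000 nM.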

Compound 4, half-maximal inhibitory concentration: 13900 nM
The estimate for compound 4 lay 4.6-fold (0.67 log units) below the measured number, and the stated range covers the measured number.
By their numbers in this assay, from the lowest: compound 1; then compound 4; then compound 3. At a limit, above all of these: compound 2.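

Placed on the six-membered aromatic ring, para to a large group, butoxy gives a real gain in this assay on a compound that carries cyclohexyl on the aromatic nitrogen, with a 3.4-fold lower number from compound 3 to compound 4 (0.53 log units; beyond the scatter). Among the compounds shown here, the second step is the first direct comparison of cyclohexyl with methyl on that nitrogen, and with butoxy present methyl gives the lower number, with a 2.7-fold higher number from compound 1 to compound 4 (0.44 log units; beyond the scatter). The data shown offer no measured explanation for either step.

Going by these compounds, it remains open whether methoxy, a longer chain or an amine at this place would give a lower number than butoxy. The size of the butoxy gain with methyl on the nitrogen also stays open, as the compounds shown offer no pair for that comparison.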